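Swapping the Aryl Group on a Set of Limit-Bound Compounds

The source may report more compounds than this note shows. Statements on the series, on what has been measured and on what is new or still open speak of the compounds shown alone.

The three measured compounds share a core carrying an anilino group and a cyclic amine, and none of them yields a number. Compound 1 `O=[N+]([O-])c1ccccc1Nc1cc(N2CCNCC2)nc2ccnn12` sits at the limit of an assay on isolated protein for inhibition of Dipeptidyl peptidase 9 (Homo sapiens) (a higher number here means a weaker inhibitor, a lower number a stronger inhibitor), giving > 100000 nM, which is a limit of the assay rather than a measured value. Compound 3 `Fc1ccc(Nc2cc(N3CCNCC3)nc3ccnn23)c(F)c1` likewise reaches only the limit in this assay, with > 100000 nM. Compound 2 `N[C@@H]1CCCN(c2cc(Nc3ccccc3Cl)n3nccc3n2)C1` is no different: in this assay compound 2 gives > 100000 nM, again a limit and not a number. Going by the values given here, compound 2 thus stands exactly where the whole set stands, at the limit of > 100000 nM in this assay, at which 3 of the 3 values shown sit, and no compound can be ordered against another.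

Compound 4 `Cc1ccc(Nc2cc(N3CCC[C@@H](N)C3)nc3ccnn23)c(C)c1` has not yet been tested. It differs from compound 2 in one place: 2,4-dimethylphenyl in place of 2-chlorophenyl on a nitrogen on an aromatic ring. Among the compounds with values here, no measured step in this set shows how such a change moves the read-out, and the measured compounds give only limits. The expected step that the limit leaves unreadable from compound 2 to compound 4 is therefore none beyond the scatter. Compound 4 is estimated at 150000 nM, within 30000 nM to 1000000 nM, with the likelier outcome that only a limit is reported again.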

Compound 4, half-maximal inhibitory concentration: > 100000 nM
Compound 4: only a limit was reported (the forecaster's own chance of this, stated with the estimate: 85%); the middle value lies beyond the limit too.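

The change from compound 2 to compound 4 yields no readable step, since both compounds give only a limit in this assay: the limit of > 100000 nM in this assay, at which 4 of the 4 values shown sit.

The compounds shown leave open whether 2,4-dimethylphenyl and 2-chlorophenyl differ at all in this assay, and what any compound's actual value would be.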